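Chain extension on the indole amide: compound 3 to compound 4

The source may hold more compounds than are shown below. What is called first, only, known or untested is meant among the compounds shown, and "the series" means these compounds.

The series shares one core, varied at the acyl group: compound 1 `CCCCCCCCCCCCNC(=O)[C@@H](NC(=O)c1ccco1)[C@@H](C)O`, compound 2 `CCCCCCCCCCCCNC(=O)[C@@H](NC(=O)c1cc2ccccc2o1)[C@@H](C)O` and compound 3 `CCCCCCCCCCCCNC(=O)[C@@H](NC(=O)c1cc2ccccc2[nH]1)[C@@H](C)O`. In a functional assay on MCF7 cells (Homo sapiens) for cytotoxicity, read by MTT assay, with a stated time of 48 h (a lower number here means a stronger inhibitor, a higher number a weaker inhibitor), compound 1 gives 67500 nM, compound 2 gives 20900 nM and compound 3 gives 12300 nM. The steps run a 3.2-fold lower number from compound 1 to compound 2 (0.51 log units; beyond the scatter) and a 5.5-fold lower number from compound 1 to compound 3 (0.74 log units; beyond the scatter), while a 1.7-fold lower number from compound 2 to compound 3 (0.23 log units; within the scatter). Compound 3 thus sits together with compound 2, clearly apart from compound 1. Compound 4 `CCCCCCCCCCCCCCCCCCNC(=O)[C@@H](NC(=O)c1cc2ccccc2[nH]1)[C@@H](C)O` differs from compound 3 by hexyl in place of hydrogen on a saturated chain carbon, ten or more bonds along the chain from an amide-type nitrogen. For the measured compounds named here, no measured step touches the chain; all three concern the group on the carbonyl carbon, so none bears on this change. Lacking any precedent, the expected step in this assay is a 1.0-fold lower number from compound 3 to compound 4 (0.01 log units; within the scatter), that is, nothing beyond the scatter. Compound 4 is estimated at 12000 nM, within 4000 nM to 40000 nM.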

Compound 4, half-maximal inhibitory concentration: 35700 nM
Compound 4: the middle estimate sits 3.0-fold (0.47 log units) below what was measured; low and high end bracket the measured number.
By their numbers in this assay, from the lowest: compounds 3, 2, 4 and 1 (each within the scatter of the next, the first and the last beyond it).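

In this assay, the chain position is not silent: with 1H-indol-2-yl held on the carbonyl carbon, hexyl in place of hydrogen gives a 2.9-fold higher number from compound 3 to compound 4 (0.46 log units; beyond the scatter). Lengthening this chain therefore does not lower the number here, and the acyl group is not the only part of the series that moves the read-out. Nothing shown accounts for this step.

A single step fixes no trend with chain length. Still open, on these data alone, are propyl at the same place, an amine or carboxylic acid on the chain, and whether hexyl acts alike with furan-2-yl or 1-benzofuran-2-yl on the carbonyl carbon.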